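Swapping Methylsulfanyl for Dimethylamino on the Thiophene Core

The source may hold more compounds than are shown below. What is called first, only, known or untested is meant among the compounds shown, and "the series" means these compounds.

In a functional assay on HL-60 cells (Homo sapiens) for antiproliferative activity, read by XTT assay, with a stated time of 72 h (on this read-out lower numbers stand for stronger inhibition and higher numbers for weaker inhibition), compound 2 `CSc1ncnc2c1c(-c1ccoc1)cn2[C@@H]1O[C@H](CO)[C@@H](O)[C@H]1O` gives 360 nM. Compound 1 `CN(C)c1ncnc2c1c(-c1ccoc1)cn2[C@@H]1O[C@H](CO)[C@@H](O)[C@H]1O` differs from it by dimethylamino in place of methylsulfanyl on an aromatic carbon, and that change made the step of a 3.2-fold higher number from compound 2 to compound 1 (0.51 log units; beyond the scatter); compound 1 gives 1160 nM. Compound 3 `CSc1ncnc2c1c(-c1cccs1)cn2[C@@H]1O[C@H](CO)[C@@H](O)[C@H]1O` differs from compound 2 by thiophen-2-yl in place of furan-3-yl on an aromatic carbon, the step being a 3.1-fold higher number from compound 2 to compound 3 (0.50 log units; beyond the scatter), and in this assay compound 3 gives 1130 nM. Compound 4 `CN(C)c1ncnc2c1c(-c1cccs1)cn2[C@@H]1O[C@H](CO)[C@@H](O)[C@H]1O` has not yet been measured. It differs from compound 3 by dimethylamino in place of methylsulfanyl on an aromatic carbon, the same change as from compound 2 to compound 1, now made on the core of compound 3. Resting on that single earlier step, a 3.2-fold higher number from compound 2 to compound 1 (0.51 log units; beyond the scatter), the expected step from compound 3 is a 3.2-fold higher number from compound 3 to compound 4 (0.50 log units; beyond the scatter). Among the measured compounds shown here, only one instance of this change has been measured, and the range is kept wide. Compound 4 is estimated at 3600 nM, between 1500 nM and 9000 nM.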

Compound 4, half-maximal inhibitory concentration: 11800 nM
Beside the measured number, compound 4's estimate is 3.3-fold (0.52 log units) below it, outside the stated range (above it).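

In this assay, dimethylamino in place of methylsulfanyl gave a higher number on the core of compound 3 as well, the step being a 10-fold higher number from compound 3 to compound 4 (1.02 log units; beyond the scatter), so the direction carried over but the size did not: the same change on two cores in this assay, a 3.2-fold higher number (0.51 log units; beyond the scatter) from compound 2 to compound 1 and a 10-fold higher number (1.02 log units; beyond the scatter) from compound 3 to compound 4, 3.2-fold (0.51 log units) apart, beyond the scatter of two such steps. Thiophen-2-yl in place of furan-3-yl behaved the same way, the step being a 10-fold higher number from compound 1 to compound 4 (1.01 log units; beyond the scatter), and again the two cores differ: the same change on two cores in this assay, a 3.1-fold higher number (0.50 log units; beyond the scatter) from compound 2 to compound 3 and a 10-fold higher number (1.01 log units; beyond the scatter) from compound 1 to compound 4, 3.2-fold (0.51 log units) apart, beyond the scatter of two such steps. The two changes therefore do not act independently across these four compounds, but two cores show neither why the steps differ nor what size the step would take on a further core.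

Still open, as far as these compounds go, is whether another amine, such as methylamino or morpholine, would follow the smaller or the larger step. The same holds for another aromatic ring, such as phenyl or furan-2-yl, in place of furan-3-yl.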